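Three Methoxy Groups on the Pendant Phenyl of Compound 3

This account rests on a few compounds, and the source may have more. Where it says the series, first, only, none or still open, it means among the compounds named here.

Three compounds share a core and differ only in one group on an aromatic carbon of the five-membered ring. Compound 1 `COc1cc(/C=C/C(=O)c2cccc(-n3cc(-c4ccc(Cl)cc4)[nH]c3=O)c2)cc(OC)c1OC` carries a 4-chlorophenyl there; in a functional assay on SF-268 cells (Homo sapiens) for inhibition (on this read-out lower numbers stand for stronger inhibition of growth and higher numbers for weaker inhibition of growth), compound 1 gives 5070 nM. Compound 2 `COc1cc(/C=C/C(=O)c2cccc(-n3cc(-c4ccccc4)[nH]c3=O)c2)cc(OC)c1OC` carries a plain phenyl and gives 1920 nM in this assay. Compound 3 `COc1ccc(-c2cn(-c3cccc(C(=O)/C=C/c4cc(OC)c(OC)c(OC)c4)c3)c(=O)[nH]2)cc1` carries a 4-methoxyphenyl and gives 3210 nM, which places it second highest of the three numbers.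

The measured steps are a 2.6-fold lower number from compound 1 to compound 2 (0.42 log units; beyond the scatter), a 1.6-fold lower number from compound 1 to compound 3 (0.20 log units; within the scatter) and a 1.7-fold higher number from compound 2 to compound 3 (0.22 log units; within the scatter). Only the first of these lies beyond the scatter; the swaps involving methoxy stayed within it.

Compound 4 `COc1cc(/C=C/C(=O)c2cccc(-n3cc(-c4cc(OC)c(OC)c(OC)c4)[nH]c3=O)c2)cc(OC)c1OC` arises from compound 3 by 3,4,5-trimethoxyphenyl in place of 4-methoxyphenyl on an aromatic carbon. Among the compounds with values here, no measured step adds two further methoxy groups, so the bearing of the data is indirect; because a 1.7-fold higher number from compound 2 to compound 3 (0.22 log units; within the scatter) was within the scatter, little movement is expected. The estimate for compound 4 is 4000 nM, ranging from 1500 nM to 11000 nM, and the expected step is a 1.2-fold higher number from compound 3 to compound 4 (0.10 log units; within the scatter) in this assay.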

Compound 4, concentration for 50% growth inhibition: 2200 nM
For compound 4 the middle estimate is 1.8-fold (0.26 log units) above the measured one; low and high end bracket the measured number.
By their numbers in this assay, from the lowest: compounds 2, 4, 3 and 1 (each within the scatter of the next, the first and the last beyond it).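

Two further methoxy groups, turning 4-methoxyphenyl into 3,4,5-trimethoxyphenyl, give a 1.5-fold lower number from compound 3 to compound 4 (0.16 log units; within the scatter) in this assay, so this position accepts the larger group, with 12 heavy atoms against 8, without a change beyond the scatter. Against the plain phenyl, the same group gives a 1.1-fold higher number from compound 2 to compound 4 (0.06 log units; within the scatter), which means that these two cannot be told apart here. Against 4-chlorophenyl, it gives a 2.3-fold lower number from compound 1 to compound 4 (0.36 log units; beyond the scatter), so a second group now stands beyond the scatter from 4-chlorophenyl, and no measurement offered here accounts for any of these differences.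

Every group shown at this position is a phenyl ring, so an amine, a carboxylic acid or a longer alkyl chain there remains an open case.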